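The source may report more compounds than this note shows. Statements on the series, on what has been measured and on what is new or still open speak of the compounds shown alone.

Measured so far:
compound 1 `Cc1cc(C)c(NC(=O)N(Cc2cccc(-c3csc(C)n3)c2)C2CCCCCC2)c(C)c1` — 180 nM
compound 2 `Cc1cc(C)c(NC(=O)N(Cc2ccc(N3CCN(C)CC3)cc2)C2CCCCCC2)c(C)c1` — 57 nM

Both were run in an assay on microsomes from intestine for inhibition of acyl-CoA:cholesterol acyltransferase (Oryctolagus cuniculus); on this read-out higher numbers stand for weaker inhibition and lower numbers for stronger inhibition. Of the two numbers, compound 1 holds the higher one; compound 2 sits further down, and that gap lies beyond the scatter, so compound 2 shows the stronger inhibition of the pair. Among the measured compounds shown here, no step between compounds differing in a single place is on record, so the effect of any one change is untested in this set.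

Compound 3 `Cc1cc(C)c(NC(=O)N(Cc2cccc(-c3cn[nH]c3)c2)C2CCCCCC2)c(C)c1` is the unmeasured member. It differs from compound 1 by 1H-pyrazol-4-yl in place of 2-methyl-1,3-thiazol-4-yl on an aromatic carbon: in words, 1H-pyrazol-4-yl in place of 2-methyl-1,3-thiazol-4-yl on an aromatic carbon. For the measured compounds named here, no measured step of this kind exists here, so its size can only be guessed. In this assay the expectation is a small shift, probably within the scatter, with a slight lean toward weaker inhibition. Compound 3 is therefore estimated at 220 nM, spanning 70 nM to 650 nM. The implied step a 1.2-fold higher number from compound 1 to compound 3 (0.09 log units; within the scatter) is expected to stay near the scatter limit.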

Compound 3, half-maximal inhibitory concentration: 38 nM
Estimate against measurement, compound 3: 5.8-fold (0.76 log units) above; measured number below the stated range.
By their numbers in this assay, from the lowest: compounds 3 and 2 (each within the scatter of the next); then compound 1.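

Among the compounds shown here, this is the first single-place step: in this assay, 1H-pyrazol-4-yl in place of 2-methyl-1,3-thiazol-4-yl on the aromatic carbon meta to a large group gives a 4.7-fold lower number from compound 1 to compound 3 (0.68 log units; beyond the scatter), a stronger inhibition beyond the scatter. The position therefore responds to the identity of the five-membered aromatic ring, although both rings carry two hetero atoms. The entering group also differs in heavy atoms, sulfur and hydrogen-bond donors, and no measured evidence separates these differences or accounts for the shift.

Still open, from the compounds shown here alone, is whether the hydrogen on the pyrazole nitrogen matters, which 1-methyl-1H-pyrazol-4-yl on the same carbon would address. Also open, going by these compounds, is how much of the step belongs to the methyl of the thiazole, which the unsubstituted 1,3-thiazol-4-yl would address.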